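Allyl series: phenyl to ethyl at the chain carbon

A few compounds are considered here, and "the series" means these few. Any claim that something is new, unique, unknown or untested is made for them only; others in the source may bear on it.

Compound 1 `CCCc1nc(C)c2cnn(CC(O)CO)c(=O)n12` gives only a limit of the assay, > 48000 nM, in a functional assay for inhibition, with Homo sapiens as the target; a lower number here means a stronger inhibitor, a higher number a weaker inhibitor. Compound 2 `C=CCn1ncc2c(C)nc(Cc3ccccc3)n2c1=O` likewise reaches only a limit, > 48000 nM, in this assay, and stands at the limit of > 48000 nM in this assay, at which 2 of the 2 values shown sit. Compound 3 `C=CCn1ncc2c(C)nc(CCC)n2c1=O` is not yet measured in this assay. It differs from compound 2 by ethyl in place of phenyl on a saturated chain carbon bound to an aromatic carbon. For the measured compounds named here, no measured step between compounds is available, so no direction can be read from the values shown. Compound 3 is expected to remain at the limit as well, an expected step that the limit leaves unreadable from compound 2 to compound 3, with an estimate of 60000 nM in the range 20000 nM to 200000 nM.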

Compound 3, half-maximal inhibitory concentration: 40000 nM
Compound 3: middle estimate off by 1.5-fold (0.18 log units), on the high side; the range from low to high includes it.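

For the compounds shown here, compound 3 gives the first readable number in this assay, so ethyl in place of phenyl on a saturated chain carbon bound to an aromatic carbon yields a value rather than a limit. That change gives an at least 1.2-fold lower number from compound 2 to compound 3 (0.07 log units; that floor lies within the scatter), and vinyl in place of 1,2-dihydroxyethyl on a saturated chain carbon bound to an aromatic nitrogen gives an at least 1.2-fold lower number from compound 1 to compound 3 (0.07 log units; that floor lies within the scatter). Both are floors only, since compounds 1 and 2 stay at a limit: the limit of > 48000 nM in this assay, at which 2 of the 3 values shown sit.

Going by these compounds, the true size of both steps remains open. Also open, on these data alone, is whether a longer chain or an amine on the chain carbon would give a lower number.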